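Working notes: amine substituent change, tolerance on kidney cells

The compounds below may be only part of what the source reports. "The series", "measured", "known", "first", "only" and "open" are said of these compounds alone.

Compound 1, `Cc1ccc2cc(CN(Cc3ccc(C(C)(C)C)cc3)Cc3cc(F)cc(F)c3)c(=O)[nH]c2c1`, in a toxicity assay on MDCK cells (Canis lupus familiaris) for cytotoxicity, read by crystal violet staining, with a stated time of 48 h (a higher number here means that more compound is tolerated, a lower number that less compound is tolerated), gives > 33000 nM, which is a limit of the assay and not a number.
Compound 2, `CCOc1ccc(CN(Cc2ccc(C(C)(C)C)cc2)Cc2cc3cc(C)ccc3[nH]c2=O)cc1`, in this assay gives > 10000 nM, again a limit of the assay and not a number.

For the measured compounds named here, compound 2 thus stands only at a limit (the limit of > 10000 nM in this assay, at which 1 of the 2 values shown sits), and the one other value is also a limit (the limit of > 33000 nM in this assay, at which 1 of the 2 values shown sits). Neither compound has a measured number, so no order between compound 1 and compound 2 can be drawn; both simply show that no half-maximal cytotoxicity was reached within the tested range.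

Compound 3, `Cc1ccc2[nH]c(=O)c(CN(Cc3ccc(C(C)(C)C)cc3)[C@H](CO)c3ccccc3)cc2c1`, is the next compound and is not yet measured in this assay. The change from compound 2 is 2-hydroxy-1-phenylethyl in place of 4-ethoxybenzyl on an amine nitrogen.

Going by the values given here, no step between measured compounds exists, so the size of the expected change rests on the structural difference alone. Because compound 2 shows > 10000 nM, the expected step that the limit leaves unreadable from compound 2 to compound 3 is none beyond the scatter. Compound 3 is expected to give about 15000 nM, within 5000 nM to 40000 nM, most likely reported again as a limit.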

Compound 3, half-maximal cytotoxic concentration: > 10000 nM
Compound 3: a limit, no number; the forecaster's own chance of this, stated with the estimate: 70%; the middle value does not contradict the limit.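

In this assay compound 3 gives > 10000 nM, a limit of the assay and not a number. For the compounds shown here, compound 2 gives > 10000 nM, also a limit, so no step from compound 2 to compound 3 can be read. The compounds shown leave open whether 2-hydroxy-1-phenylethyl in place of 4-ethoxybenzyl on the amine nitrogen changes tolerance at all.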